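The source may hold more compounds than are shown below. What is called first, only, known or untested is meant among the compounds shown, and "the series" means these compounds.

In a functional assay on T47D cells (Homo sapiens) for inhibition, read by CCK-8 assay, with a stated time of 72 h, tested at 1 uM (on this read-out higher numbers stand for more inhibition of growth at the one concentration tested and lower numbers for less inhibition of growth), compound 2 `CN(C)C(=O)c1cc2cnc(Nc3ccc(NC(=O)C4(C(=O)Nc5cccc(C(F)(F)F)c5)CC4)cc3)nc2n1C1CCCC1` gives 9.7%, the lower of the two numbers available, while compound 1 `CN(C)C(=O)c1cc2cnc(Nc3ccc(NC(=O)C4(C(=O)Nc5ccc(Br)cc5)CC4)cc3)nc2n1C1CCCC1` gives 21.1%. The open question concerns compound 3 `CN(C)C(=O)c1cc2cnc(Nc3ccc(NC(=O)C4(C(=O)Nc5ccc(C(F)(F)F)cc5)CC4)cc3)nc2n1C1CCCC1`, which has not yet been measured. Its change is 4-(trifluoromethyl)phenyl in place of 3-(trifluoromethyl)phenyl on an amide-type nitrogen. Within the data shown here, one measured step bears on this, a number 11.4 percentage points lower from compound 1 to compound 2 (beyond the scatter), where 3-(trifluoromethyl)phenyl replaced 4-bromophenyl on that same nitrogen. That step alters both the group and its printed position number, so it offers only a weak guide, and no direct comparison of the two trifluoromethyl groups has been measured. A modest rise is therefore expected in this assay, an estimated a number 10.3 percentage points higher from compound 2 to compound 3 (beyond the scatter). Compound 3 is expected to give 20%, with an estimated range of 7% to 33%.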

Compound 3, percent growth inhibition at one concentration: 29.6%
The estimate for compound 3 lay 9.6 percentage points below the measured number; the measured number falls inside the stated range.
By their numbers in this assay, from the lowest: compound 2; then compounds 1 and 3 (each within the scatter of the next).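

The two trifluoromethyl isomers can now be compared directly: in this assay the change to 4-(trifluoromethyl)phenyl on the amide-type nitrogen gives a number 19.9 percentage points higher from compound 2 to compound 3 (beyond the scatter) and shows that where the trifluoromethyl group sits on this phenyl ring matters, even though the two compounds have the same atoms. Trifluoromethyl in place of bromo on an aromatic carbon gives a number 8.5 percentage points higher from compound 1 to compound 3 (within the scatter) and so does not separate these two substituents on this read-out. Nothing available explains the difference between the two isomers.

The compounds shown leave open whether a methoxy group, an amine or a carboxylic acid on this phenyl ring would fit the same trend. They also do not show how 3-bromophenyl compares with 4-bromophenyl on that nitrogen.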